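The source may hold more compounds than are shown below. What is called first, only, known or untested is meant among the compounds shown, and "the series" means these compounds.

Measured compounds:
compound 1 `OC[C@H]1O[C@@H](n2cnc3c(CSCc4ccccc4)ncnc32)[C@H](O)[C@@H]1O` with > 100000 nM in a functional assay on Huh-7 cells (Homo sapiens) for cytotoxicity, read by MTT assay, with a stated time of 3 days; on this read-out higher numbers stand for lower toxicity in this test and lower numbers for higher toxicity in this test
compound 2 `O=c1ccn(Cc2ncnc3c2ncn3[C@@H]2O[C@H](CO)[C@@H](O)[C@H]2O)cc1` with > 100000 nM in this assay
compound 3 `CC(=O)N(Cc1ncnc2c1ncn2[C@@H]1O[C@H](CO)[C@@H](O)[C@H]1O)C1CCCCC1` with > 100000 nM in this assay

All three of these results are limits of this assay rather than numbers. Compound 2 stands at that limit, and the two further results shown also sit at a limit, so no ordering among the three is readable. Going by the values given here, the one step between measured compounds, a step that the two limits leave unreadable from compound 1 to compound 2, is therefore of unreadable size; it describes (the limit of > 100000 nM in this assay, at which 3 of the 3 values shown sit), which is where every value shown rests.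

The unmeasured compound 4 `O=c1ccccn1Cc1ncnc2c1ncn2[C@@H]1O[C@H](CO)[C@@H](O)[C@H]1O` differs from compound 2 by a group of 7 heavy atoms (5 carbon, 1 nitrogen, 1 oxygen; one six-membered aromatic ring with 1 hetero atom) in place of a group of 7 heavy atoms (5 carbon, 1 nitrogen, 1 oxygen; one six-membered aromatic ring with 1 hetero atom), on a saturated chain carbon bound to an aromatic carbon. Among the compounds with values here, no measured step bears directly on this change, and the only step available is itself unreadable. What is known is that compound 2, compound 1 and compound 3 all return only a limit in this assay, with changes to the group on the saturated chain carbon bound to an aromatic carbon leaving that outcome unchanged. Compound 4 is therefore expected to remain at or beyond the same limit in this assay, with an estimated value of 150000 nM (range 50000 nM to 500000 nM). The step from compound 2 to compound 4 is expected to be a step that the limit leaves unreadable from compound 2 to compound 4, not readable beyond the scatter.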

Compound 4, half-maximal cytotoxic concentration: > 100000 nM
Compound 4 ended at the assay's limit (the forecaster's own chance of this, stated with the estimate: 85%); the middle value does not contradict the limit.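

Compound 4, like compound 1 and compound 2, returned only a limit in this assay and not a number, so no new step among these compounds can be read. The results shown all rest at one limit: the limit of > 100000 nM in this assay, at which 4 of the 4 values shown sit. The compounds shown leave open whether this assay would return a number for any change to the group on the saturated chain carbon bound to an aromatic carbon.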